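The compounds below may be only part of what the source reports. "The series", "measured", "known", "first", "only" and "open" are said of these compounds alone.

Compound 1 `C=C(Br)C(=O)Nc1ccc(/C=C/C(=O)c2cccc(OC)c2)cc1` and compound 2 `C=C(Br)C(=O)Nc1ccc(/C=C/C(=O)c2cc(OC)c(OC)c(OC)c2)cc1` share an amide bearing a (1-bromoethenyl)carbonyl group; how their two cores differ is not broken down here. In a functional assay on L1210 cells (Mus musculus) for antiproliferative activity, with a stated time of 48 h (on this read-out lower numbers stand for stronger inhibition and higher numbers for weaker inhibition), compound 1 gives 2100 nM and compound 2 gives 910 nM. Compound 3 `COc1cccc(C(=O)/C=C/c2ccc(N)cc2)c1` carries hydrogen in place of (1-bromoethenyl)carbonyl on a nitrogen on an aromatic ring relative to compound 1, and in this assay compound 3 gives 38000 nM; the step of an 18-fold higher number from compound 1 to compound 3 (1.26 log units; beyond the scatter). Compound 4 `COc1cc(C(=O)/C=C/c2ccc(N)cc2)cc(OC)c1OC` differs from compound 2 by hydrogen in place of (1-bromoethenyl)carbonyl on a nitrogen on an aromatic ring, the same change at a place described in the same words. For compound 4 an expected step of about an 18-fold higher number from compound 2 to compound 4 (1.25 log units; beyond the scatter) in this assay rests on compound 1 having moved an 18-fold higher number from compound 1 to compound 3 (1.26 log units; beyond the scatter) under this change. Compound 4 is therefore estimated at 16000 nM, with an expected range from 5000 nM to 50000 nM.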

Compound 4, half-maximal inhibitory concentration: 14000 nM
Beside the measured number, compound 4's estimate is 1.1-fold (0.06 log units) above it, within the range that was stated.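

Taking away the (1-bromoethenyl)carbonyl group to leave the free amino group in this assay again gives a large step, a 15-fold higher number from compound 2 to compound 4 (1.19 log units; beyond the scatter). The two steps agree: the same change on two cores in this assay, an 18-fold higher number (1.26 log units; beyond the scatter) from compound 1 to compound 3 and a 15-fold higher number (1.19 log units; beyond the scatter) from compound 2 to compound 4, 1.2-fold (0.07 log units) apart, within the scatter of two such steps. The change therefore carries over between these two cores in this assay, but a single pair of cores does not show that it would carry over to any other core in the series, and it does not explain why the step is so large.

The compounds shown leave open whether the step follows the bromine, the double bond or the amide itself. A plain acetyl group or a propenoyl group without bromine on that nitrogen would bear on this question.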